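The compounds below may be only part of what the source reports. "The series", "measured", "known", "first", "only" and "open" are said of these compounds alone.

In a functional assay on ZR-75-1 cells (Homo sapiens) for inhibition, read by sulforhodamine B assay (a lower number here means a stronger inhibitor of growth, a higher number a weaker inhibitor of growth), compound 1 `COc1ccc(-c2ccc(-c3ccc(-c4nc5ccccc5[nH]4)cc3)cc2)cc1OC` gives 39700 nM and compound 2 `CN(C)c1ccc(-c2ccc(-c3ccc(-c4nc5c(O)cccc5[nH]4)cc3)cc2)cc1` gives 4100 nM. Compound 2 holds the lower of the two numbers, and the gap between them lies beyond the scatter. Compound 3 `COc1ccc(-c2ccc(-c3ccc(-c4nc5c(O)cccc5[nH]4)cc3)cc2)cc1OC` has not yet been measured. It departs from compound 2 in one place: 3,4-dimethoxyphenyl in place of 4-(dimethylamino)phenyl on an aromatic carbon. Among the measured compounds shown here, no measured pair differs in one place only, so the series offers no direct measure of this change. For the measured compounds named here, the only guide is compound 1, which also bears 3,4-dimethoxyphenyl and gives 39700 nM. A modest shift to a higher number, meaning weaker growth inhibition, is therefore expected in this assay, slightly beyond the scatter. The estimated step is a 2.4-fold higher number from compound 2 to compound 3 (0.39 log units; beyond the scatter). For compound 3 the estimate is 10000 nM, with an expected range of 3000 nM to 30000 nM.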

Compound 3, concentration for 50% growth inhibition: 2110 nM
Compound 3: middle estimate off by 4.7-fold (0.68 log units), on the high side; the measured number lies below the stated range.
By their numbers in this assay, from the lowest: compounds 3 and 2 (each within the scatter of the next); then compound 1.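

In this assay, 3,4-dimethoxyphenyl in place of 4-(dimethylamino)phenyl, on an aromatic carbon para to a large group, gives a 1.9-fold lower number from compound 2 to compound 3 (0.29 log units; within the scatter), so with the hydroxy present these two groups are not told apart at this position. Hydroxy in place of hydrogen on an aromatic carbon gives a 19-fold lower number from compound 1 to compound 3 (1.27 log units; beyond the scatter) as the first direct measure of that change, a large step read with 3,4-dimethoxyphenyl held constant. Nothing at hand bears on the origin of either step.

On these data alone, the hydroxy step rests on this single pair, so its size with 4-(dimethylamino)phenyl stays open. Also open, as far as these compounds go, is whether a methoxy, an amine or a fluorine in place of the hydroxy would give a step of similar size.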